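The source may report more compounds than this note shows. Statements on the series, on what has been measured and on what is new or still open speak of the compounds shown alone.

Within the data shown here, compound 1 `CC1=CC[C@@H]([C@@](C)(O)CCCC(C)(C)NC(=S)N/N=C\c2ccc(O)cc2)CC1` gives 8390 nM in a functional assay on NCI/ADR cells (Homo sapiens) for cytotoxicity, read by sulforhodamine B assay (on this read-out lower numbers stand for stronger inhibition of growth and higher numbers for weaker inhibition of growth), the lowest of the two numbers measured so far. Compound 2 `CC1=CC[C@@H]([C@@](C)(O)CCCC(C)(C)NC(=S)N/N=C\c2ccc(N(C)C)cc2)CC1` gives 25200 nM, and the step of a 3.0-fold higher number from compound 1 to compound 2 (0.48 log units; beyond the scatter) came with dimethylamino in place of hydroxy on an aromatic carbon. Compound 3 `CC1=CC[C@@H]([C@@](C)(O)CCCC(C)(C)NC(=S)N/N=C\c2ccc(Cl)cc2)CC1` differs from compound 1 by chloro in place of hydroxy on an aromatic carbon. Among the measured compounds shown here, that one measured step is the only guide; it also removed the hydroxy and weakened growth inhibition modestly. For compound 3 a modest weakening is therefore expected, with the step of a 1.8-fold higher number from compound 1 to compound 3 (0.25 log units; within the scatter). The estimate for compound 3 in this assay is 15000 nM, within 6000 nM to 40000 nM.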

Compound 3, concentration for 50% growth inhibition: 7580 nM
Beside the measured number, compound 3's estimate is 2.0-fold (0.30 log units) above it, within the range that was stated.
By their numbers in this assay, from the lowest: compounds 3 and 1 (each within the scatter of the next); then compound 2.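

In this assay, a 1.1-fold lower number from compound 1 to compound 3 (0.04 log units; within the scatter), so at this place, para to a large group, chloro can stand for hydroxy although it has no hydrogen-bond donor or acceptor. Loss of the hydroxy alone therefore does not go with weaker growth inhibition, and dimethylamino stands apart, with a 3.3-fold lower number from compound 2 to compound 3 (0.52 log units; beyond the scatter). No measurement here accounts for these numbers. Going by these compounds, whether methoxy, a primary amine or a carboxylic acid at this place would match hydroxy and chloro or dimethylamino remains open.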